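The source may hold more compounds than are shown below. What is called first, only, known or untested is meant among the compounds shown, and "the series" means these compounds.

Working notes on the series.

Compound 1 `CCOC(=O)C1=Cc2ccccc2OC1(OCc1cn(CC(=O)Nc2cccc(F)c2)nn1)C(F)(F)F` is the point of departure. In a functional assay on DU-145 cells (Homo sapiens) for inhibition, read by MTT assay, with a stated time of 24 h (on this read-out higher numbers stand for weaker inhibition and lower numbers for stronger inhibition), compound 1 gives > 150000 nM. That value is a limit of the assay and not a measured number, so compound 1 stands only at the edge of what the assay resolves; (the limit of > 150000 nM in this assay, at which 1 of the 2 values shown sits). For the measured compounds named here, a second member, compound 2 `CCOC(=O)C1=Cc2ccccc2OC1(OCc1cc(-c2ccc(F)cc2)no1)C(F)(F)F`, differs from compound 1 in more than one place, so no single step between the two is counted here. In this assay compound 2 gives 53500 nM, a number rather than a limit, which shows that the shared core of compound 1 can reach a readable value when the five-membered ring and its substituent are changed.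

The next member, compound 3 `CCOC(=O)C1=Cc2ccccc2OC1(OCc1cn(-c2cccc(OC)c2)nn1)C(F)(F)F`, keeps the core of compound 1 and changes only one place: 3-methoxyphenyl in place of ((3-fluorophenyl)carbamoyl)methyl on an aromatic nitrogen. Going by the values given here, because compound 1 sits at the limit (the limit of > 150000 nM in this assay, at which 1 of the 2 values shown sits), no measured step tells how this change should read. The expected step from compound 1 to compound 3 is therefore uncertain in direction, and a change within the usual scatter, an at least 1.5-fold lower number from compound 1 to compound 3 (0.17 log units; that floor lies within the scatter), is as likely as a gain. Compound 3 is expected to give about 100000 nM, within 30000 nM to 300000 nM.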

Compound 3, half-maximal inhibitory concentration: > 150000 nM
Compound 3 was reported as a limit (the forecaster's own chance of this, stated with the estimate: 45%); middle value at least 1.5-fold (0.17 log units) away from the limit.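

For the compounds shown here, compound 3, like compound 1, is reported in this assay only as a limit and not as a number, so no step between compound 1 and compound 3 can be read: (the limit of > 150000 nM in this assay, at which 2 of the 3 values shown sit). The compounds shown leave open how 3-methoxyphenyl and ((3-fluorophenyl)carbamoyl)methyl on an aromatic nitrogen compare, since neither gives a readable value on the shared core.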